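Aryl change at the sulfonyl sulfur: expectation for compound 4

A few compounds are considered here, and "the series" means these few. Any claim that something is new, unique, unknown or untested is made for them only; others in the source may bear on it.

Three compounds on a shared core have been run in an assay on isolated protein for displacement of a labelled ligand from metabotropic glutamate receptor 5 (Homo sapiens), with a stated time of 60 min, tested at 1 uM; a higher number here means more inhibition at the concentration tested (going by the name of the read-out), a lower number less inhibition. Compound 1 `CC1CCN(c2c(S(=O)(=O)c3ccc(Cl)cc3)cnc3ccc(F)cc23)CC1` gives 80%. Compound 2 `Cc1cc(C)cc(S(=O)(=O)c2cnc3ccc(F)cc3c2N2CCC(C)CC2)c1` gives 83%. Compound 3 `Cc1ccc(S(=O)(=O)c2cnc3ccc(F)cc3c2N2CCC(C)CC2)cc1C` gives 92%, the highest of the three numbers, though its gap to compound 2 lies within the scatter and only its gap to compound 1 lies beyond it. The measured steps are a number 3 percentage points higher from compound 1 to compound 2 (within the scatter), a number 12 percentage points higher from compound 1 to compound 3 (beyond the scatter) and a number 9 percentage points higher from compound 2 to compound 3 (within the scatter).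

Compound 4 `CC1CCN(c2c(S(=O)(=O)c3cccc(Cl)c3)cnc3ccc(F)cc23)CC1` has not yet been measured. It differs from compound 3 by 3-chlorophenyl in place of 3,4-dimethylphenyl on a sulfonyl sulfur. Within the data shown here, the step that bears most directly on this change is a number 12 percentage points higher from compound 1 to compound 3 (beyond the scatter), in which a chlorophenyl group gave way to the 3,4-dimethylphenyl group; the change to compound 4 runs back toward a chlorophenyl, now as 3-chlorophenyl rather than 4-chlorophenyl, and no measured pair separates those two. A modest fall, roughly reversing that step, is therefore expected; the expected step is a number 10 percentage points lower from compound 3 to compound 4 (within the scatter). In this assay compound 4 is estimated to give 82%, with a range from 70% to 92%.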

Compound 4, a percentage reported as inhibition, at one concentration (the size of the read-out at that concentration, not a potency): 92%
Compound 4: the middle estimate sits 10 percentage points below what was measured; low and high end bracket the measured number.
By their numbers in this assay, from the lowest: compounds 1, 2, 3 and 4 (each within the scatter of the next, the first and the last beyond it).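

In this assay, a chlorophenyl group on the sulfonyl sulfur does not by itself bring the lower number: no change at the digits printed from compound 3 to compound 4 (within the scatter), with 3-chlorophenyl replacing 3,4-dimethylphenyl. Among these compounds, the placement of chlorine in the group's name matters in this pair, with a number 12 percentage points higher from compound 1 to compound 4 (beyond the scatter), the first measured step that separates 3-chlorophenyl from 4-chlorophenyl, and it lies beyond the scatter. Against the other dimethylphenyl group the result is not resolved, with a number 9 percentage points higher from compound 2 to compound 4 (within the scatter), so 3-chlorophenyl cannot be ordered against 3,5-dimethylphenyl.

Still open, from the compounds shown here alone, is how this position responds to a phenyl group carrying an amine or a carboxylic acid, or to a straight alkyl chain in place of the aryl group. No measurement at hand accounts for the gap between the two chlorophenyl groups.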